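Difluorophenyl pattern change in the nitrile series

This account rests on a few compounds, and the source may have more. Where it says the series, first, only, none or still open, it means among the compounds named here.

Compound 1, `C[C@@H](C(=O)N[C@H](C#N)CC(N)=O)N(Cc1ccc(-c2cc(F)cc(F)c2)cc1)S(C)(=O)=O`, gives 1360 nM.
Compound 2, `C[C@H](C(=O)N[C@H](C#N)CC(N)=O)N(Cc1ccc(-c2cc(F)cc(F)c2)cc1)S(C)(=O)=O`, gives 9250 nM.
Compound 3, `CS(=O)(=O)N(CC(=O)N[C@H](C#N)CC(N)=O)Cc1ccc(-c2cccc(F)c2F)cc1`, gives > 10000 nM.

All three results come from an assay on isolated protein for inhibition of legumain (Homo sapiens), with stated times of 2 min and 60 min; a lower number here means a stronger inhibitor, a higher number a weaker inhibitor. Compound 1 holds the lowest number of the two numbers available; the nearest is compound 2, with a 6.8-fold higher number from compound 1 to compound 2 (0.83 log units; beyond the scatter), the two differing in nothing but configuration as drawn (the fact that compounds 1 and 2 differ only in the configuration as drawn). For compound 3 the result is a limit of this assay (the limit of > 10000 nM in this assay, at which 1 of the 3 values shown sits), not a number, and compound 3 differs from compound 1 in more than one place, so no single step can be read from it.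

The next compound, compound 4, `C[C@@H](C(=O)N[C@H](C#N)CC(N)=O)N(Cc1ccc(-c2ccc(F)c(F)c2)cc1)S(C)(=O)=O`, carries 3,4-difluorophenyl in place of 3,5-difluorophenyl on an aromatic carbon, the new group sitting on an aromatic carbon of a six-membered aromatic ring of carbon only, para to a large group. For the measured compounds named here, no measured step touches this kind of change: the one step available concerns a stereocentre, and the limit of compound 3 cannot be scaled. With nothing pointing either way, the step from compound 1 is expected to stay within the scatter, as a 1.1-fold higher number from compound 1 to compound 4 (0.04 log units; within the scatter). Compound 4 is therefore estimated at 1500 nM in this assay, within a range from 500 nM to 5000 nM.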

Compound 4, half-maximal inhibitory concentration: 252 nM
Compound 4: middle estimate off by 6.0-fold (0.77 log units), on the high side; measured number outside the range, below it.
By their numbers in this assay, from the lowest: compound 4; then compound 1; then compound 2. At a limit, above all of these: compound 3.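

On the aromatic carbon para to a large group, rearranging the fluorines from 3,5-difluorophenyl to 3,4-difluorophenyl gives a 5.4-fold lower number from compound 1 to compound 4 (0.73 log units; beyond the scatter) in this assay, so this position responds to the fluorine pattern alone. For the compounds shown here, the leaving and entering groups have the same counts of heavy atoms, hydrogen-bond donors and hydrogen-bond acceptors, and neither carries a net charge, so none of these counted features separates compound 1 from compound 4; before this pair, the only readable step concerned a stereocentre. Nothing measured here gives a reason for the shift.

Open, from the compounds shown here alone, is whether 3,4-difluorophenyl would hold its lower number against a 3,4-dichlorophenyl or a 4-methoxyphenyl group on the same carbon, and whether the step carries over to the configuration drawn in compound 2. Compound 3, at > 10000 nM, is a limit of the assay and not a number, and it differs from compound 1 and compound 4 in more than one place, so its steps cannot be read.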